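Methyl at the Chain Carbon: Expected Clearance of Compound 4

This account rests on a few compounds, and the source may have more. Where it says the series, first, only, none or still open, it means among the compounds named here.

Measured compounds:
compound 1 `COc1cnc(-c2ccccn2)nc1NCc1ccccc1Cl`: 704 mL/min/kg
compound 2 `COc1cnc(-c2ccccn2)nc1NCc1ccccc1C`: 901 mL/min/kg
compound 3 `COc1cnc(-c2ccccn2)nc1NCc1ccccc1`: 911 mL/min/kg

In an in vitro ADME assay on microsomes from liver (Mus musculus) for metabolic stability, read by LC-MS, tested at 0.05 uM (a lower number here means slower removal, a higher number faster removal of the compound), compound 3 gives 911 mL/min/kg. Its steps from the other two, a 1.3-fold higher number from compound 1 to compound 3 (0.11 log units; within the scatter) and a 1.0-fold higher number from compound 2 to compound 3 (0.00 log units; within the scatter), both lie within the scatter, so compound 3 stands together with compound 1 and compound 2 rather than apart from them.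

Compound 4 `COc1cnc(-c2ccccn2)nc1NC(C)c1ccccc1` differs from compound 3 in one place: methyl in place of hydrogen on a saturated chain carbon bound to an aromatic carbon and a nitrogen on an aromatic ring. The measured steps, a 1.3-fold higher number from compound 1 to compound 2 (0.11 log units; within the scatter), a 1.3-fold higher number from compound 1 to compound 3 (0.11 log units; within the scatter) and a 1.0-fold higher number from compound 2 to compound 3 (0.00 log units; within the scatter), all concern an aromatic carbon and all stay within the scatter; none touches the saturated chain carbon. Within the data shown here, no measured step bears directly on this change. Compound 4 is therefore expected to stay close to compound 3, an estimated step of a 1.1-fold lower number from compound 3 to compound 4 (0.06 log units; within the scatter), within the scatter. Compound 4 is estimated at 800 mL/min/kg, in the range 450 mL/min/kg to 1400 mL/min/kg.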

Compound 4, clearance: 570 mL/min/kg
Estimate against measurement, compound 4: 1.4-fold (0.15 log units) above; the measured number falls inside the stated range.
By their numbers in this assay, from the lowest: compounds 4, 1, 2 and 3 (each within the scatter of the next).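

Among these compounds, for the first time the saturated chain carbon has a measured step of its own in this assay, and the step of a 1.6-fold lower number from compound 3 to compound 4 (0.20 log units; within the scatter) shows that this position tolerates methyl in place of hydrogen without leaving the scatter. Changes on the chain carbon and on the aromatic carbon have so far both stayed within the scatter. No evidence is available that accounts for this result.

The compounds shown leave open whether ethyl or a second methyl on this chain carbon would also stay within the scatter. They also leave open how the methyl behaves alongside the chloro of compound 1.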